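A Phenyl in Place of the 5-Hydroxypentyl Chain

The compounds below may be only part of what the source reports. "The series", "measured", "known", "first", "only" and "open" are said of these compounds alone.

Compound 1 `CSc1nc(NCCCCCO)c2ccccc2n1` carries a 5-hydroxypentyl group on a nitrogen of its aromatic core. In a functional assay on HT-29 cells (Homo sapiens) for cytotoxicity, read by MTT assay, with a stated time of 72 h (a lower number here means that less compound is tolerated, a higher number that more compound is tolerated), compound 1 gives > 100000 nM, which is a limit of the assay rather than a number. Compound 2 `CSc1nc(NCCCc2ccccc2)c2ccccc2n1` gives > 100000 nM, likewise a limit. Compound 3 `CCCCCSc1nc(O)c2ccccc2n1` gives > 100000 nM, also a limit. The step that the two limits leave unreadable from compound 1 to compound 2 is therefore unreadable, and the limit of > 100000 nM in this assay, at which 3 of the 3 values shown sit, shows every measured value resting at that limit. Compound 4 `CSc1nc(Nc2ccccc2)c2ccccc2n1` differs from compound 1 as follows: phenyl in place of 5-hydroxypentyl on a nitrogen on an aromatic ring. Among the compounds with values here, no measured step can size this change, so no step beyond the scatter is expected, a number no higher from compound 1 to compound 4 (the limit leaves the size open). Compound 4 is therefore expected to give about 100000 nM, within 30000 nM to 300000 nM, most likely again reported only as a limit.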

Compound 4, concentration lethal to 50% of the cells: > 100000 nM
Compound 4 gave a limit, no number (the forecaster's own chance of this, stated with the estimate: 75%); the middle value lies on the limit itself.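

No step from compound 1 to compound 4 can be read, as both rest at the same limit: the limit of > 100000 nM in this assay, at which 4 of the 4 values shown sit.

The compounds shown leave open whether phenyl and 5-hydroxypentyl on that nitrogen differ at all in their effect on the cells.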